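A few compounds are considered here, and "the series" means these few. Any claim that something is new, unique, unknown or untested is made for them only; others in the source may bear on it.

Of the compounds shown here, three of one series have so far been measured in a functional assay, with a stated time of 150 min; a higher number here means a weaker inhibitor, a lower number a stronger inhibitor. Compound 1 `CSc1nc(-c2cccs2)c(C#N)c(=O)n1C` gives 87 ug/mL in this assay. Compound 2 `CSc1nc(-c2ccccc2O)c(C#N)c(=O)n1C` gives 58 ug/mL, and compound 3 `Cn1c(NN)nc(-c2ccccc2O)c(C#N)c1=O` gives 46 ug/mL. The difference between the cores of compound 1 and compound 2 is not broken down here. Compound 2 and compound 3 differ in one place only, (aminoamino in place of methylsulfanyl on an aromatic carbon), and that change brought a 1.3-fold lower number from compound 2 to compound 3 (0.10 log units; within the scatter).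

Compound 4 `Cn1c(NN)nc(-c2cccs2)c(C#N)c1=O` has not yet been measured. It carries the same kind of change on the core of compound 1: aminoamino in place of methylsulfanyl on an aromatic carbon. The surroundings differ in one respect: in compound 1 the changed carbon is meta to a thiophen-2-yl group of 5 heavy atoms, whereas in compound 2 it is meta to a group of 7 heavy atoms.

The expectation for compound 4 rests on this single earlier instance, which gave a 1.3-fold lower number from compound 2 to compound 3 (0.10 log units; within the scatter), and on compound 1 with its value of 87 ug/mL. For compound 4 a small step is therefore expected, a 1.3-fold lower number from compound 1 to compound 4 (0.11 log units; within the scatter). Compound 4 is estimated to give about 67 ug/mL in this assay, between 35 ug/mL and 130 ug/mL.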

Compound 4, half-maximal inhibitory concentration: 63 ug/mL
Compound 4: middle estimate off by 1.1-fold (0.03 log units), on the high side, and the stated range covers the measured number.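

Replacing methylsulfanyl with aminoamino on the core of compound 1 gave, in this assay, a 1.4-fold lower number from compound 1 to compound 4 (0.14 log units; within the scatter). Set beside the earlier instance on the core of compound 2, the two results agree: the same change on two cores in this assay, a 1.3-fold lower number (0.10 log units; within the scatter) from compound 2 to compound 3 and a 1.4-fold lower number (0.14 log units; within the scatter) from compound 1 to compound 4, 1.1-fold (0.04 log units) apart, within the scatter of two such steps. This shows that, on these two cores, the change carried over without any detectable difference in its outcome, but it does not show that aminoamino has a real effect of its own, as neither step stands clear of the scatter, and two cores say nothing about how the change would behave on others.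

The compounds shown leave open whether another group on that aromatic carbon, such as a simple amine, a methoxy group or a longer alkylsulfanyl chain, would move the number beyond the scatter. As far as these compounds go, it also remains open whether the outcome would hold on a core carrying something other than the thiophen-2-yl group, such as a carboxylic acid-bearing phenyl ring.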